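The source may hold more compounds than are shown below. What is called first, only, known or untested is meant among the compounds shown, and "the series" means these compounds.

Compound 1 `CC(C)(C)C1=NN(c2ccc(Cl)cc2Cl)C(c2ccc(O)cc2)C1` and compound 3 `CC(C)(C)C1=NN(c2ccc(Cl)cc2)C(c2ccc(Br)cc2)C1` share their core with compound 2 `CC(C)(C)C1=NN(c2ccc(F)c(Cl)c2)C(c2ccc(O)cc2)C1` and with the not yet tested compound 4 `CC(C)(C)C1=NN(c2ccc(Cl)cc2)C(c2ccc(O)c(F)c2)C1`. In an assay on U-937 cells for inhibition of protein kinase C zeta type (Homo sapiens), read by reporter gene assay (a higher number here means a weaker inhibitor, a lower number a stronger inhibitor), compound 1 gives "not determined" (no result reported), and compound 3 gives "not determined" (no result reported), so compound 3 stands without any number to its name. In this assay compound 2 gives 1900 nM. Compound 4 differs from compound 3 by 3-fluoro-4-hydroxyphenyl in place of 4-bromophenyl on a saturated ring carbon. Among the compounds with values here, no pair of measured compounds shows this step, so its size and direction in this assay are unknown, and the expectation can rest only on compound 2, which gives 1900 nM in this assay. Compound 4 is therefore expected to give about 2000 nM in this assay, within a range from 600 nM to 7000 nM.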

Compound 4, half-maximal inhibitory concentration: 3700 nM
For compound 4 the middle estimate is 1.9-fold (0.27 log units) below the measured one; the measured number falls inside the stated range.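

Within the data shown here, compound 3 has no number and compound 2 differs from compound 4 in more than one place, so compound 4 yields no new step. What 3-fluoro-4-hydroxyphenyl in place of 4-bromophenyl does alone stays open, and no measurement shown speaks to a cause.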